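Hydrazone aryl swap: pyridin-4-yl for 4-hydroxyphenyl

The source may report more compounds than this note shows. Statements on the series, on what has been measured and on what is new or still open speak of the compounds shown alone.

The series shares one core and varies the aryl group on the carbon with a double bond to nitrogen. Compound 1 `Cc1c(C(=O)N/N=C\c2ccc(O)cc2)oc2cccc(O)c12` gives 21700 nM in a functional assay on PC-3 cells (Homo sapiens) for inhibition; a lower number here means a stronger inhibitor, a higher number a weaker inhibitor. Compound 3 `Cc1c(C(=O)N/N=C\c2cccc(O)c2)oc2cccc(O)c12` gives 17600 nM in this assay, and the step of a 1.2-fold lower number from compound 1 to compound 3 (0.09 log units; within the scatter). Compound 2 `Cc1c(C(=O)N/N=C\c2ccccn2)oc2cccc(O)c12` reaches only the limit >= 40000 nM in this assay, a limit and not a number. Among the two numbers shown, compound 1 holds the higher one, with compound 3 as nearest neighbour. Going by the values given here, the step of an at least 1.8-fold higher number from compound 1 to compound 2 (0.26 log units; that floor lies within the scatter) rests on (the limit of >= 40000 nM in this assay, at which 1 of the 3 values shown sits), and the step of an at least 2.2-fold lower number from compound 2 to compound 3 (0.35 log units; beyond the scatter) is the one step here beyond the scatter.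

Compound 4 `Cc1c(C(=O)N/N=C\c2ccncc2)oc2cccc(O)c12` is the next member. Its change from compound 1 is pyridin-4-yl in place of 4-hydroxyphenyl on a carbon with a double bond to nitrogen. Among the compounds with values here, the step from compound 1 to compound 2 is the nearest precedent: a pyridinyl in place of a hydroxyphenyl on that carbon gave a higher number, up to the limit. By the same token a higher number is expected for compound 4, with a real chance that this assay again returns only a limit. The step expected is a 1.6-fold higher number from compound 1 to compound 4 (0.21 log units; within the scatter). Compound 4 is therefore estimated at 35000 nM, within a range from 15000 nM to 80000 nM.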

Compound 4, half-maximal inhibitory concentration: >= 40000 nM
Compound 4 was reported as a limit; the forecaster's own chance of this, stated with the estimate: 45%; middle value at least 1.1-fold (0.05 log units) from the limit.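

In this assay compound 4 gives >= 40000 nM, which is a limit and not a number. The series now reads the same way for pyridin-4-yl as for pyridin-2-yl on the carbon with a double bond to nitrogen: both pyridinyl compounds, compound 2 and compound 4, end at a limit, while the two hydroxyphenyl compounds, compound 1 and compound 3, give numbers. The floor of an at least 2.2-fold higher number from compound 3 to compound 4 (0.35 log units; beyond the scatter) adds a second step beyond the scatter at this place, whereas the floor of an at least 1.8-fold higher number from compound 1 to compound 4 (0.26 log units; that floor lies within the scatter) does not clear it, and the shared limit caps what can be read from either step: the limit of >= 40000 nM in this assay, at which 2 of the 4 values shown sit.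

As far as these compounds go, the step between compound 2 and compound 4 cannot be read, so these notes cannot order pyridin-2-yl and pyridin-4-yl, and how far either compound lies from the limit remains unknown. Also open, from the compounds shown here alone, is whether a plain phenyl, an aminophenyl or a carboxyphenyl group on that carbon would return a number in this assay, and whether any such group would read differently from the hydroxyphenyl pair.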